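The source may report more compounds than this note shows. Statements on the series, on what has been measured and on what is new or still open speak of the compounds shown alone.

Working notes on the series. Three compounds share one core and differ in the group on the amide nitrogen of that core. Compound 1 `CCCCCCCC(=O)Nc1nc2ccc(NC(=O)c3c(Cl)cccc3Cl)cc2s1` gives 0.18 ug/mL in a functional assay on WI-38 VA13 cells (Homo sapiens) for cytotoxicity; on this read-out lower numbers stand for an effect already at smaller amounts and higher numbers for an effect only at larger amounts of compound; compound 2 `NCCC(=O)Nc1nc2ccc(NC(=O)c3c(Cl)cccc3Cl)cc2s1` gives 5.3 ug/mL; compound 3 `COC(=O)Nc1nc2ccc(NC(=O)c3c(Cl)cccc3Cl)cc2s1` gives 0.0095 ug/mL and stands lowest of the three numbers, with the steps of a 19-fold lower number from compound 1 to compound 3 (1.28 log units; beyond the scatter) and a 560-fold lower number from compound 2 to compound 3 (2.75 log units; beyond the scatter) both well beyond the scatter. Compound 4 `CC(C)COC(=O)Nc1nc2ccc(NC(=O)c3c(Cl)cccc3Cl)cc2s1` has not yet been measured; it differs from compound 3 by isopropyl in place of hydrogen on a saturated chain carbon bound to an oxygen next to a carbonyl group. Among the compounds with values here, no measured step makes this change; the nearest is a 19-fold lower number from compound 1 to compound 3 (1.28 log units; beyond the scatter), where a longer chain on the carbonyl carbon went with a higher number. A moderate rise is therefore expected, a 3.2-fold higher number from compound 3 to compound 4 (0.50 log units; beyond the scatter), giving for compound 4 an estimated 0.03 ug/mL within 0.008 ug/mL to 0.12 ug/mL.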

Compound 4, half-maximal effective concentration: 0.0035 ug/mL
Compound 4: middle estimate off by 8.6-fold (0.93 log units), on the high side; the whole stated range lies above it.
By their numbers in this assay, from the lowest: compound 4; then compound 3; then compound 1; then compound 2.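

In this assay, isopropyl in place of hydrogen on the saturated chain carbon bound to an oxygen next to a carbonyl group gives a 2.7-fold lower number from compound 3 to compound 4 (0.43 log units; beyond the scatter), so this position accepts a larger branched group without a rise in the number. On the carbonyl carbon, isobutoxy stands far from heptyl, a 51-fold lower number from compound 1 to compound 4 (1.71 log units; beyond the scatter), and further still from 2-aminoethyl, a 1500-fold lower number from compound 2 to compound 4 (3.18 log units; beyond the scatter), so group size alone does not order these four compounds. Nothing at hand explains these differences.

Open, as far as these compounds go, is whether a longer chain on that oxygen, such as hexyl, continues the step from methoxy to isobutoxy. Also open, from the compounds shown here alone, is how an amine at the end of such a chain would compare with isobutoxy.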